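A few compounds are considered here, and "the series" means these few. Any claim that something is new, unique, unknown or untested is made for them only; others in the source may bear on it.

Compound 3, `CCCCOC(=O)Nc1ccc([Se]C#N)cc1`, is the starting point of this step. In a functional assay on HTB-54 cells (Homo sapiens) for cytotoxicity, read by MTT assay, with a stated time of 72 h (on this read-out lower numbers stand for stronger inhibition of growth and higher numbers for weaker inhibition of growth), compound 3 gives 43400 nM. Two related compounds have been measured in the same way: compound 2, `CCCOC(=O)Nc1ccc([Se]C#N)cc1`, gives 51900 nM in this assay, and compound 1, `CC(C)COC(=O)Nc1ccc([Se][Se]c2ccc(NC(=O)OCC(C)C)cc2)cc1`, gives 52900 nM. All three numbers lie within the usual scatter of one another, so compound 3 cannot be set apart from either of its neighbours on the numbers shown.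

Among the compounds with values here, the only measured step that differs in one place is the one from compound 2 to compound 3, a 1.2-fold lower number from compound 2 to compound 3 (0.08 log units; within the scatter), which adds a methyl to the carbamate chain and leaves the read-out essentially unchanged.

Compound 4, `CC(C)COC(=O)Nc1ccc([Se]C#N)cc1`, is the next compound in this series. It differs from compound 3 by isopropyl in place of propyl on a saturated chain carbon bound to an oxygen next to a carbonyl group. The same isobutyl carbamate already appears in compound 1, whose value sits within the scatter of compound 3. Within the data shown here, the one measured chain change left the number where it was, and compound 1 gives no sign that the branched chain moves it either, so no step beyond the scatter is expected. The expected step from compound 3 to compound 4 is a 1.0-fold higher number from compound 3 to compound 4 (0.02 log units; within the scatter), giving an estimated value for compound 4 of 45000 nM with a range from 25000 nM to 80000 nM.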

Compound 4, concentration for total growth inhibition: 51200 nM
The estimate for compound 4 lay 1.1-fold (0.06 log units) below the measured number; the range from low to high includes it.
By their numbers in this assay, from the lowest: compounds 3, 4, 2 and 1 (each within the scatter of the next).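

In this assay, isopropyl in place of propyl on a saturated chain carbon bound to an oxygen next to a carbonyl group gives a 1.2-fold higher number from compound 3 to compound 4 (0.07 log units; within the scatter), so the butoxy and isobutoxy chains cannot be told apart on these numbers. The earlier compounds shown here had tested only an unbranched extension of the chain, whereas compound 4 adds a branch: methyl in place of hydrogen on a saturated chain carbon bound to two saturated chain carbons gives a 1.0-fold lower number from compound 2 to compound 4 (0.01 log units; within the scatter), which also lies within the usual scatter, so among compounds 2, 3 and 4 neither lengthening nor branching the chain separates one from another. No measurement given here bears on why these chains read alike.

The carbamate chains shown are all short saturated carbon chains, so it remains open whether a much longer chain, a benzyl group or a chain ending in an amine would give a step beyond the scatter. Going by these compounds, it also remains open whether this lack of separation among compounds 2, 3 and 4 would hold in cells other than the line tested here.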